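Aryl-to-Pyridyl Amide Swap on a Weak Cell-Growth Inhibitor

The compounds below may be only part of what the source reports. "The series", "measured", "known", "first", "only" and "open" are said of these compounds alone.

Compounds measured so far:
Compound 1 `Cc1noc(C)c1-c1cnc(N)c(Oc2ccc(C(=O)Nc3ccc(Cl)cc3)cc2)n1`; in a functional assay on U-87MG ATCC cells for inhibition, with U-87 MG (Homo sapiens) as the target, read by MTT assay, with a stated time of 72 h (a higher number here means a weaker inhibitor, a lower number a stronger inhibitor), compound 1 gives 15500 nM.
Compound 2 `Cc1noc(C)c1-c1cnc(N)c(Oc2ccc(C(=O)Nc3cccc(Cl)c3)cc2)n1`; in this assay compound 2 gives 11500 nM.

Among the compounds with values here, compound 2 holds the lowest of the two numbers, yet its only neighbour, compound 1, stands within the scatter of it: the step of a 1.3-fold lower number from compound 1 to compound 2 (0.13 log units; within the scatter) does not separate the two, so neither can be called the stronger inhibitor. Both are weak by the scale of this read-out.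

Compound 3 `Cc1noc(C)c1-c1cnc(N)c(Oc2ccc(C(=O)Nc3ccc(Cl)cn3)cc2)n1` is the next analogue, differing from compound 2 by 5-chloropyridin-2-yl in place of 3-chlorophenyl on an amide-type nitrogen. Within the data shown here, no measured step bears directly on an exchange of a carbocyclic ring for a nitrogen-containing one at this amide nitrogen; the single step available, a 1.3-fold lower number from compound 1 to compound 2 (0.13 log units; within the scatter), concerns a different alteration of the same ring and fell within the scatter. With nothing to point either way, compound 3 is expected to stay close to compound 2, and the step of a 1.0-fold lower number from compound 2 to compound 3 (0.02 log units; within the scatter) is estimated to lie within the scatter. Compound 3 is therefore estimated at 11000 nM, with a range from 4000 nM to 30000 nM.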

Compound 3, half-maximal inhibitory concentration: 45600 nM
Compound 3: the middle estimate sits 4.1-fold (0.62 log units) below what was measured, and the stated range ends below it.
By their numbers in this assay, from the lowest: compounds 2 and 1 (each within the scatter of the next); then compound 3.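

In this assay, the group on the amide-type nitrogen proved able to shift the number beyond the scatter, which the exchange between the two chlorophenyl groups had not shown. Placing 5-chloropyridin-2-yl there instead of 3-chlorophenyl gives a 4.0-fold higher number from compound 2 to compound 3 (0.60 log units; beyond the scatter), and placing it there instead of 4-chlorophenyl gives a 2.9-fold higher number from compound 1 to compound 3 (0.47 log units; beyond the scatter), so compound 3 is the weakest inhibitor of the three, whichever chlorophenyl compound it is set against. By count, the exchange brings one ring nitrogen and one hydrogen-bond acceptor, but nothing measured here accounts for the higher number.

The compounds shown leave open whether the loss follows from the ring nitrogen in general or is tied to the 5-chloropyridin-2-yl group, the only nitrogen-containing ring among them. They also leave open how plain pyridin-2-yl, or a pyridin-2-yl ring carrying a methoxy or a nitrile in place of the chlorine, would read in this assay, and whether any such group would bring the number back towards those of compound 1 and compound 2.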